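Nitrogen substituents: from compound 3 to compound 4

This account rests on a few compounds, and the source may have more. Where it says the series, first, only, none or still open, it means among the compounds named here.

In a functional assay on NCI-H2286 cells (Homo sapiens) for antiproliferative activity, read by CCK-8 assay, with a stated time of 72 h (a higher number here means a weaker inhibitor, a lower number a stronger inhibitor), compound 1 (`Cc1ccc(C(=O)Nc2cccc(C(F)(F)F)c2)cc1-c1ccc2c(-c3cn[nH]c3)n[nH]c2c1`) gives > 1000 nM, which is a limit of the assay. Compound 2 (`Cc1ccc(C(=O)Nc2cccc(C(F)(F)F)c2)cc1-c1ccc2c(-c3cnn(C)c3)n[nH]c2c1`) gives 24.3 nM. Compound 3 (`Cc1ccc(C(=O)Nc2cccc(C(F)(F)F)c2)cc1-c1ccc2c(-c3cnn(CC(C)O)c3)n[nH]c2c1`) gives 196 nM, the higher of the two actual numbers, and the gap between them is an 8.1-fold higher number from compound 2 to compound 3 (0.91 log units; beyond the scatter).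

Compound 4 (`Cc1ccc(C(=O)Nc2cccc(C(F)(F)F)c2)cc1-c1ccc2c(-c3cnn(C4CCOC4)c3)n[nH]c2c1`) carries oxolan-3-yl in place of 2-hydroxypropyl on an aromatic nitrogen.

Going by the values given here, three measured steps bear on this change: an at least 41-fold lower number from compound 1 to compound 2 (1.61 log units; beyond the scatter), an at least 5.1-fold lower number from compound 1 to compound 3 (0.70 log units; beyond the scatter) and the gap above. Both substituents on that nitrogen gave lower numbers than hydrogen, and they differ modestly from each other. A modest move to a lower number is therefore expected, a 2.5-fold lower number from compound 3 to compound 4 (0.39 log units; beyond the scatter). Compound 4 is estimated at 80 nM, with an expected range of 20 nM to 350 nM.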

Compound 4, half-maximal inhibitory concentration: 69.7 nM
Beside the measured number, compound 4's estimate is 1.1-fold (0.06 log units) above it, and the stated range covers the measured number.
By their numbers in this assay, from the lowest: compound 2; then compound 4; then compound 3. At a limit, above all of these: compound 1.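

In this assay, oxolan-3-yl on this aromatic nitrogen, with a ring and no hydrogen-bond donor, improves on 2-hydroxypropyl, a 2.8-fold lower number from compound 3 to compound 4 (0.45 log units; beyond the scatter), so a donor on this substituent is not required, yet it does not reach methyl, a 2.9-fold higher number from compound 2 to compound 4 (0.46 log units; beyond the scatter). Against hydrogen, the ring also gives a clear gain, an at least 14-fold lower number from compound 1 to compound 4 (1.15 log units; beyond the scatter). Compound 1 stands only as a limit: the limit of > 1000 nM in this assay, at which 1 of the 4 values shown sits.

The ring and the loss of the hydroxyl change together here, and the compounds shown do not separate them. As far as these compounds go, whether an amine, a carboxylic acid or a longer chain on this nitrogen would match methyl remains open.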